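Working notes: one double bond, two drawn configurations

The source may report more compounds than this note shows. Statements on the series, on what has been measured and on what is new or still open speak of the compounds shown alone.

- compound 1 `CC/C(=C(/c1ccccc1)c1ccc(NC(=O)C(C)C)cc1)c1ccc(Cl)cc1Cl` at 8200 nM
- compound 2 `CC/C(=C(\c1ccc(O)cc1)c1ccc(NC(=O)C(C)C)cc1)c1ccc(Cl)cc1Cl` at 8700 nM

In a functional assay on HeLa cells (Homo sapiens) for inhibition, read by trypan blue exclusion, with a stated time of 72 h (on this read-out lower numbers stand for stronger inhibition of growth and higher numbers for weaker inhibition of growth), compound 1 gives 8200 nM and compound 2 gives 8700 nM with no gap beyond the scatter, so compound 2 stands level with compound 1 and the two cannot be ranked. Compound 3 `CC/C(=C(/c1ccc(O)cc1)c1ccc(NC(=O)C(C)C)cc1)c1ccc(Cl)cc1Cl` remains unmeasured. Its relation to compound 2 is the two compounds have the same atoms and bonds and differ only in configuration as drawn: 1 of 1 stereo elements differ; a double bond is drawn E in compound 2 and Z in compound 3 and nothing else: nothing leaves, nothing enters, and a double bond is drawn E in compound 2 and Z in compound 3. For the measured compounds named here, no step between measured compounds exists to size such a change. Going by the values given here, the only numbers at hand are compound 1 at 8200 nM and compound 2 at 8700 nM and they say nothing direct about configuration. On that thin basis no step beyond the scatter is expected in this assay and no direction is favoured. For compound 3 the estimated value is 8000 nM with an expected range from 4000 nM to 16000 nM in the same read-out. The estimate amounts to an expected step of a 1.1-fold lower number from compound 2 to compound 3 (0.04 log units; within the scatter) and no more.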

Compound 3, concentration for 50% growth inhibition: 20300 nM
Beside the measured number, compound 3's estimate is 2.5-fold (0.40 log units) below it; the whole stated range lies below it.
By their numbers in this assay, from the lowest: compounds 1 and 2 (each within the scatter of the next); then compound 3.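

Configuration at the double bond is shown here to count in this assay, which the earlier compounds could not show, and the size of the change is a 2.3-fold higher number from compound 2 to compound 3 (0.37 log units; beyond the scatter), a modest step that can be tied to one thing alone: the fact that compounds 2 and 3 differ only in the configuration as drawn. The hydroxy in place of hydrogen on an aromatic carbon also carries a modest step in the same direction, weaker inhibition of growth, at a 2.5-fold higher number from compound 1 to compound 3 (0.39 log units; beyond the scatter). Within these three compounds, then, the hydroxy and the drawn configuration have to be read together, since compound 3 is the only compound that stands apart, with compounds 1 and 2 level within the scatter.

Open, on these data alone, is whether a methoxy or an amine in place of the hydroxy would show the same dependence on the drawn configuration. Also open, as far as these compounds go, is whether the order of compound 2 and compound 3 holds on any cell line or read-out other than this assay, as a single pair gives no pattern for the series.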